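A second chlorine on compound 3

The source may hold more compounds than are shown below. What is called first, only, known or untested is meant among the compounds shown, and "the series" means these compounds.

Compound 1 `Cc1ccc(S(=O)(=O)N[C@@H](CC(=O)NC(C)(C)C)C(=O)NCCNC(=O)c2cccc(C(C)C)c2)cc1`, compound 2 `Cc1ccc(S(=O)(=O)N[C@@H](CC(=O)NC(C)(C)C)C(=O)NCCNC(=O)c2ccc(F)cc2)cc1` and compound 3 `Cc1ccc(S(=O)(=O)N[C@@H](CC(=O)NC(C)(C)C)C(=O)NCCNC(=O)c2ccc(Cl)cc2)cc1` share a core and differ in the aromatic group on a carbonyl carbon. In an ADME assay on HepG2 cells (Homo sapiens) for cytotoxicity (a lower number here means that less compound is needed, a higher number that more compound is needed for the effect), compound 1 gives > 11000 nM, which is a limit of the assay and not a number. Compound 2 gives > 11000 nM, also a limit. Compound 3 gives > 11000 nM, again a limit. For the measured compounds named here, the series so far is summed up as the limit of > 11000 nM in this assay, at which 3 of the 3 values shown sit.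

Compound 4 `Cc1ccc(S(=O)(=O)N[C@@H](CC(=O)NC(C)(C)C)C(=O)NCCNC(=O)c2cc(Cl)ccc2Cl)cc1` carries 2,5-dichlorophenyl in place of 4-chlorophenyl on a carbonyl carbon. Going by the values given here, three measured steps bear on this change: a step that the two limits leave unreadable from compound 1 to compound 2, a step that the two limits leave unreadable from compound 1 to compound 3 and a step that the two limits leave unreadable from compound 2 to compound 3. None of them has a size that can be read, so they give no direction. In this assay no shift beyond the scatter is expected, and the expected step is a step that the limit leaves unreadable from compound 3 to compound 4. Another limit is the likeliest report. Compound 4 is estimated at 15000 nM. The expected range for compound 4 runs from 9000 nM to 40000 nM.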

Compound 4, half-maximal effective concentration: > 11000 nM
Compound 4 was reported as a limit; the forecaster's own chance of this, stated with the estimate: 90%; the middle value is on the limit's open side.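

In this assay compound 4 gives > 11000 nM, which is a limit and not a number. None of its steps from compound 1, compound 2 and compound 3 can be read. The compounds shown leave open whether the aromatic group on the carbonyl carbon changes this read-out at all, and the series stands at: the limit of > 11000 nM in this assay, at which 4 of the 4 values shown sit.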